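Swapping methoxy for chloro on the pendant phenyl ring

The compounds below may be only part of what the source reports. "The series", "measured", "known", "first", "only" and "open" are said of these compounds alone.

Of the compounds shown here, three sharing one core have been measured in a functional assay on K562 cells (Homo sapiens) for inhibition; a higher number here means a weaker inhibitor of growth, a lower number a stronger inhibitor of growth. Compound 1 `COc1cc(/C=C/C(=O)c2cccc(-n3cc(-c4ccccc4)[nH]c3=O)c2)ccc1O` gives 2040 nM. Compound 2 `O=C(/C=C/c1cccc(O)c1)c1cccc(-n2cc(-c3ccc(Cl)cc3)[nH]c2=O)c1` gives 400 nM. Compound 3 `COc1ccc(-c2cn(-c3cccc(C(=O)/C=C/c4ccc(O)c(OC)c4)c3)c(=O)[nH]2)cc1` gives 2350 nM, the highest number of the three, close to compound 1 and far from compound 2, which sits clearly lower.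

Compound 4 `COc1cc(/C=C/C(=O)c2cccc(-n3cc(-c4ccc(Cl)cc4)[nH]c3=O)c2)ccc1O` is not yet measured. It differs from compound 3 by chloro in place of methoxy on an aromatic carbon. Going by the values given here, the one measured step that touches the same ring, a 1.2-fold higher number from compound 1 to compound 3 (0.06 log units; within the scatter), shows that adding or removing a methoxy there changed nothing beyond the scatter. Among the compounds with values here, no measured step shows chloro alone entering at this position: compound 2 carries the chloro group but differs from compound 4 in more than one place, so its lower number cannot be assigned to the chloro group with confidence.

The expectation for compound 4 is therefore a modest move downward, a 1.8-fold lower number from compound 3 to compound 4 (0.26 log units; within the scatter), leaning toward compound 2 but uncertain. Compound 4 is estimated at 1300 nM in this assay, within a range from 450 nM to 3500 nM.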

Compound 4, concentration for 50% growth inhibition: 1420 nM
Beside the measured number, compound 4's estimate is 1.1-fold (0.04 log units) below it, and the stated range covers the measured number.
By their numbers in this assay, from the lowest: compound 2; then compounds 4, 1 and 3 (each within the scatter of the next).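

At the position para to a large group on the pendant phenyl ring, the comparison in this assay now covers three groups: chloro in place of methoxy gives a 1.7-fold lower number from compound 3 to compound 4 (0.22 log units; within the scatter), chloro in place of hydrogen gives a 1.4-fold lower number from compound 1 to compound 4 (0.16 log units; within the scatter), and so hydrogen, methoxy and chloro cannot be told apart here. With the 4-chlorophenyl group held constant, the change on the double-bonded chain, 4-hydroxy-3-methoxyphenyl in place of 3-hydroxyphenyl, gives a 3.6-fold higher number from compound 2 to compound 4 (0.55 log units; beyond the scatter), so the low number of compound 2 cannot be credited to chloro alone and goes with the other aromatic group in this comparison. No measured information is available to explain either result.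

Going by these compounds, it remains open whether a quite different group at the same position, such as an amine or a carboxylic acid, would shift the number beyond the scatter. On these data alone, it is also open whether the 3-hydroxyphenyl group would give a similarly low number with hydrogen or methoxy on the pendant ring instead of chloro.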